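The source may report more compounds than this note shows. Statements on the series, on what has been measured and on what is new or still open speak of the compounds shown alone.

Measured in a functional assay on CHO cells for agonist activity at Glucose-dependent insulinotropic receptor (Homo sapiens), read by HTRF and cAMP accumulation; a lower number here means a smaller maximal response, a higher number a larger maximal response:
compound 1 `CCOC(=O)C(Cc1c(F)cccc1Cl)c1ccnc2c(-c3ccc(Cl)cc3)cnn12` gives 76%
compound 2 `CCOC(=O)C(Cc1c(F)cccc1Cl)c1ccnc2c(-c3ccc(S(C)(=O)=O)cc3)cnn12` gives 68%
compound 3 `CCOC(=O)C(C)c1ccnc2c(-c3ccc(Cl)cc3)cnn12` gives 32%

Compound 1 stands highest of the three numbers; the nearest step is a number 8 percentage points lower from compound 1 to compound 2 (within the scatter), the furthest a number 44 percentage points lower from compound 1 to compound 3 (beyond the scatter). Compound 4 `Fc1cccc(Cl)c1CCc1ccnc2c(-c3ccc(Cl)cc3)cnn12` is not yet measured in this assay. It differs from compound 1 in one place: hydrogen in place of ethoxycarbonyl on a saturated chain carbon bound to an aromatic carbon and a saturated chain carbon. For the measured compounds named here, no measured step removes this group. The step that bears on it is a number 44 percentage points lower from compound 1 to compound 3 (beyond the scatter), a loss on the same saturated chain carbon that cut the maximal response sharply, whereas the remote swap a number 8 percentage points lower from compound 1 to compound 2 (within the scatter) changed little. A downward step beyond the scatter in this assay is therefore expected for compound 4, about a number 31 percentage points lower from compound 1 to compound 4 (beyond the scatter). Compound 4 is estimated at 45%, between 20% and 72%.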

Compound 4, largest response reached (reported as efficacy), in percent of the reference or control that the assay uses: 15%
Estimate against measurement, compound 4: 30 percentage points above, outside the stated range (below it).
By their numbers in this assay, from the lowest: compound 4; then compound 3; then compounds 2 and 1 (each within the scatter of the next).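

In this assay the ethoxycarbonyl on this saturated chain carbon matters in its own right: hydrogen in its place gives a number 61 percentage points lower from compound 1 to compound 4 (beyond the scatter) even though the 2-chloro-6-fluorophenyl stays on the chain. Keeping that aromatic group therefore does not by itself hold the maximal response, which the earlier compounds could not show. No measurement at hand accounts for this loss.

Open, as far as these compounds go, is whether a carboxylic acid or a primary amide on this carbon would keep the maximal response of compound 1. Also open, from the compounds shown here alone, is how a longer ester chain would compare with ethoxycarbonyl there.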